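Two Values at the Assay Limit, a Third Compound Awaited

The source may hold more compounds than are shown below. What is called first, only, known or untested is meant among the compounds shown, and "the series" means these compounds.

Compound 1 `NNC(=O)CCc1ccncc1-c1ccc2ccccc2c1` was examined in a functional assay on A549 cells (Homo sapiens) for inhibition, read by sulforhodamine B assay, with a stated time of 72 h; on this read-out higher numbers stand for weaker inhibition of growth and lower numbers for stronger inhibition of growth. In this assay compound 1 gives > 10000 nM, which is a limit of the assay and not a measured number. Compound 2 `CNC(=O)/C=C/c1ccncc1-c1ccc2[nH]ccc2c1` was examined in the same way. In this assay compound 2 gives > 10000 nM, again a limit rather than a number. Going by the values given here, compound 1 therefore stands where the only other value stands as well, at the edge of what the assay can report: the limit of > 10000 nM in this assay, at which 2 of the 2 values shown sit.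

Compound 3 `O=C(/C=C/c1ccncc1-c1ccc2ccccc2c1)NC1CC1` has not yet been measured in this assay. It differs from compound 1 in a single place: 2-(cyclopropylcarbamoyl)ethenyl in place of 2-(aminocarbamoyl)ethyl on an aromatic carbon. Among the compounds with values here, no step between two measured compounds is known, so the effect of this kind of change cannot be read from any measured pair here. Given that compound 1 sits at the limit of > 10000 nM in this assay, at which 2 of the 2 values shown sit, no step beyond the scatter is expected in either direction, and the expected step is a step that the limit leaves unreadable from compound 1 to compound 3. For compound 3 the estimate in this assay is 15000 nM, with a range from 3000 nM to 60000 nM, and it is expected that the assay will most likely again report only a limit.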

Compound 3, concentration for 50% growth inhibition: 5840 nM
Beside the measured number, compound 3's estimate is 2.6-fold (0.41 log units) above it; the range from low to high includes it.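

In this assay compound 3 gives 5840 nM, the only value among the compounds shown that is a number and not a limit, so a group at this position, opposite the ring nitrogen, can go with growth inhibition that the assay is able to report. Putting 2-(cyclopropylcarbamoyl)ethenyl in place of 2-(aminocarbamoyl)ethyl on the shared core gives an at least 1.7-fold lower number from compound 1 to compound 3 (0.23 log units; that floor lies within the scatter), which means that this change is tied to a lower number, but only a floor for its size can be stated. The true size of the step cannot be read because the starting point is not a measured number: the limit of > 10000 nM in this assay, at which 2 of the 3 values shown sit.

The change alters two parts at once, the ethyl link becoming an ethenyl link and the amino end giving way to a cyclopropyl end, and the compounds shown do not separate what each part contributes. Also open, going by these compounds, is how this assay would respond to a carboxylic acid or a longer chain at this same position on the shared core.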